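Swapping fluoro for hydroxy on the ring of compound 2

This account rests on a few compounds, and the source may have more. Where it says the series, first, only, none or still open, it means among the compounds named here.

Compound 1 `O=C(CSc1nnc(-c2ccncc2)n1-c1ccccc1)N/N=C/c1ccc(F)cc1`: 12300 nM
Compound 2 `O=C(CSc1nnc(-c2ccncc2)n1-c1ccccc1)N/N=C/c1ccccc1F`: 22400 nM
Compound 3 `O=C(CSc1nnc(-c2ccncc2)n1-c1ccccc1)N/N=C/c1ccccc1O`: not yet measured

Of the compounds shown here, two have been measured in a functional assay on MCF7 cells (Homo sapiens) for inhibition, read by MTT assay, with a stated time of 48 h; on this read-out higher numbers stand for weaker inhibition and lower numbers for stronger inhibition. Compound 1 gives 12300 nM, and compound 2 gives 22400 nM. Compound 2 stands alongside compound 1: the step of a 1.8-fold higher number from compound 1 to compound 2 (0.26 log units; within the scatter) lies within the scatter, so the two cannot be told apart. Compound 3 differs from compound 2 in one place: hydroxy in place of fluoro on an aromatic carbon. Within the data shown here, no measured step involves this exchange. Among the measured compounds shown here, the only step available moved a fluoro group from one position to another and left the number unchanged within the scatter; it says nothing about a hydroxy group. With nothing to lean on, no step beyond the scatter is expected in this assay in either direction, though the range is kept wide. Compound 3 is therefore estimated at 20000 nM, between 6000 nM and 65000 nM, a step of a 1.1-fold lower number from compound 2 to compound 3 (0.05 log units; within the scatter) that is expected to stay within the scatter.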

Compound 3, half-maximal inhibitory concentration: 10000 nM
Beside the measured number, compound 3's estimate is 2.0-fold (0.30 log units) above it; the measured number falls inside the stated range.
By their numbers in this assay, from the lowest: compounds 3, 1 and 2 (each within the scatter of the next, the first and the last beyond it).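

Among these compounds, this is the first exchange of one group for a different group at this place, on an aromatic carbon ortho to a large group, and in this assay it gives a 2.2-fold lower number from compound 2 to compound 3 (0.35 log units; beyond the scatter), a modest step just past the usual scatter. The other comparison, a 1.2-fold lower number from compound 1 to compound 3 (0.09 log units; within the scatter), stays within the scatter, so the 2-hydroxyphenyl and 4-fluorophenyl versions cannot be told apart in this read-out. Hydroxy adds a hydrogen-bond donor and acceptor that fluoro lacks, but nothing measured here explains the step.

The compounds shown leave open whether a hydroxy group on another carbon of this ring would give a similar number. They also leave open how a methoxy group or an amine on this same carbon would compare with hydroxy.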